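Exchanging the amide aryl group: from aminophenyl to pyridin-2-yl

A few compounds are considered here, and "the series" means these few. Any claim that something is new, unique, unknown or untested is made for them only; others in the source may bear on it.

Compound 1 `O=C(Nc1nnc(-c2ccc3c(c2)OCCO3)s1)c1ccccc1`: in a functional assay on HeLa cells (Homo sapiens) for antiproliferative activity, read by MTT assay, with a stated time of 48 h (a higher number here means that more compound is needed for the effect, a lower number that less compound is needed), compound 1 gives > 100 ug/mL, a limit of the assay.
Compound 2 `Nc1ccc(C(=O)Nc2nnc(-c3ccc4c(c3)OCCO4)s2)cc1`: in this assay compound 2 gives > 100 ug/mL, a limit of the assay.
Compound 3 `O=C(/C=C/c1ccccc1)Nc1nnc(-c2ccc3c(c2)OCCO3)s1`: in this assay compound 3 gives > 100 ug/mL, a limit of the assay.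

Compound 2 stands at the limit, and so do both companions, as the limit of > 100 ug/mL in this assay, at which 3 of the 3 values shown sit, records. The steps a step that the two limits leave unreadable from compound 1 to compound 2, a step that the two limits leave unreadable from compound 2 to compound 3 and a step that the two limits leave unreadable from compound 1 to compound 3 are therefore all unreadable. Compound 4 `O=C(Nc1nnc(-c2ccc3c(c2)OCCO3)s1)c1ccccn1` arises from compound 2 by the change (pyridin-2-yl in place of 4-aminophenyl on a carbonyl carbon). Among the measured compounds shown here, no measured step tells how this change acts, so no step beyond the scatter in this assay can be predicted in either direction. Compound 4 is therefore expected to sit near the limit as well, estimated at 150 ug/mL within 60 ug/mL to 400 ug/mL. The step that the limit leaves unreadable from compound 2 to compound 4 is thus expected to be essentially nil.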

Compound 4, half-maximal effective concentration: > 100 ug/mL
Compound 4 was reported as a limit; the forecaster's own chance of this, stated with the estimate: 80%; the middle value lies beyond the limit too.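

Compound 4 joins compound 1, compound 2 and compound 3 at the limit, so none of the steps among them can be read: the limit of > 100 ug/mL in this assay, at which 4 of the 4 values shown sit.

The compounds shown leave open whether exchanging the group on the carbonyl carbon changes the effect at all in this assay.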